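From 4-fluorophenyl to 2,4-dichlorophenyl: one swap, one open question

The compounds below may be only part of what the source reports. "The series", "measured", "known", "first", "only" and "open" are said of these compounds alone.

Compound 1 `O=[N+]([O-])c1ccc(Nc2nccc(-c3ccc(F)cc3)n2)cc1`: 7950 nM
Compound 2 `CC(C)c1ccccc1Nc1nccc(-c2ccc(Br)cc2)n1`: 7030 nM

In a functional assay on HepG2 cells (Homo sapiens) for antiproliferative activity, read by MTT assay (a higher number here means a weaker inhibitor, a lower number a stronger inhibitor), compound 1 gives 7950 nM, and this lies within the usual scatter of the value for compound 2. Compound 3 `O=[N+]([O-])c1ccc(Nc2nccc(-c3ccc(Cl)cc3Cl)n2)cc1` keeps the core of compound 1 but has 2,4-dichlorophenyl in place of 4-fluorophenyl on an aromatic carbon. Going by the values given here, no measured pair isolates a single change. Although it differs from compound 1 in more than one place, compound 2 gives 7030 nM, so little change is expected here. The estimated 1.3-fold lower number from compound 1 to compound 3 (0.12 log units; within the scatter) is not expected to go beyond the scatter. For compound 3, the estimated value is 6000 nM, with an expected range from 2000 nM to 18000 nM.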

Compound 3, half-maximal inhibitory concentration: 99300 nM
Compound 3: middle estimate off by 17-fold (1.22 log units), on the low side, outside the stated range (above it).
By their numbers in this assay, from the lowest: compounds 2 and 1 (each within the scatter of the next); then compound 3.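

In this assay, placing 2,4-dichlorophenyl where compound 1 carries 4-fluorophenyl gives a 12-fold higher number from compound 1 to compound 3 (1.10 log units; beyond the scatter), so compound 3 is a clearly weaker inhibitor. This position on the shared core is therefore sensitive: a single swap of one aromatic group for another can cost much of the activity. Nothing measured here explains the loss.

As far as these compounds go, whether it follows from both chlorines together or from only one of them stays open. So does how 4-chlorophenyl, or a phenyl ring bearing an amine, would behave at this position.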